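A few compounds are considered here, and "the series" means these few. Any claim that something is new, unique, unknown or untested is made for them only; others in the source may bear on it.

Compound 1 `CCCc1cc(N)c2cc(NC(=O)/C=C/c3ccc(Cl)cc3)ccc2n1` is one of three compounds that share a core and differ in the group carried on the amide. In an assay on isolated protein for displacement of a labelled ligand from melanin-concentrating hormone receptor 1 (Homo sapiens) (on this read-out higher numbers stand for weaker inhibition and lower numbers for stronger inhibition), compound 1 gives 6 nM. Compound 3 `CC(C)(C)c1cc(N)c2cc(NC(=O)/C=C/c3ccc(C(F)(F)F)cc3)ccc2n1` gives 0.3 nM, while compound 2 `CCCc1cc(N)c2cc(NC(=O)CCc3ccccc3)ccc2n1` gives 8300 nM. Compound 1 thus stands second highest of the three, with compound 3 nearest and compound 2 furthest, both gaps lying beyond the scatter. Compound 4 `CCCc1cc(N)c2cc(NC(=O)/C=C/c3ccc(CC)cc3)ccc2n1` has not been measured and differs from compound 1 by ethyl in place of chloro on an aromatic carbon. For the measured compounds named here, no measured pair shows this change, so its effect in this assay is unknown; a step no larger than the scatter is expected, in either direction. Compound 4 is expected to give 10 nM, between 2 nM and 50 nM. That estimate means an expected step of a 1.7-fold higher number from compound 1 to compound 4 (0.22 log units; within the scatter).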

Compound 4, half-maximal inhibitory concentration: 1.4 nM
Beside the measured number, compound 4's estimate is 7.1-fold (0.85 log units) above it, and the stated range ends above it.
By their numbers in this assay, from the lowest: compound 3; then compound 4; then compound 1; then compound 2.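

For the compounds shown here, putting ethyl in place of chloro gives a 4.3-fold lower number from compound 1 to compound 4 (0.63 log units; beyond the scatter) in this assay and this is the first direct reading at this position. Chlorine is not needed here for strong inhibition, and the two-carbon ethyl group gives a modest gain over the single chlorine atom. Nothing shown explains that gain.

As far as these compounds go, it remains open how a longer chain such as propyl, a methoxy group or an amine would read at this same place. Whether the same swap holds on the core of compound 3 is also unknown.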